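Aryl substituent change from compound 3 to compound 4

The compounds below may be only part of what the source reports. "The series", "measured", "known", "first", "only" and "open" are said of these compounds alone.

Values measured in a functional assay on U-251 cells (Homo sapiens) for inhibition, read by sulforhodamine B assay, with a stated time of 48 h; on this read-out lower numbers stand for stronger inhibition of growth and higher numbers for weaker inhibition of growth:
compound 1 `CC1=CC[C@H](C(C)(C)NC(=S)N/N=C/c2ccc(F)cc2)CC1`: > 100000 nM
compound 2 `CC1=CC[C@H](C(C)(C)NC(=S)N/N=C(\C)c2ccccc2)CC1`: > 100000 nM
compound 3 `COc1ccc(/C(C)=N/NC(=S)NC(C)(C)[C@H]2CC=C(C)CC2)cc1`: > 100000 nM

In this assay compound 3 gives > 100000 nM, a limit of the assay and not a number. Among the compounds with values here, all three values sit at the limit of > 100000 nM in this assay, at which 3 of the 3 values shown sit, so no compound can be ordered against another. The step that the two limits leave unreadable from compound 2 to compound 3 is the only one touching the same aromatic position, and its size cannot be read.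

Compound 4 `CC1=CC[C@H](C(C)(C)NC(=S)N/N=C(\C)c2ccc([N+](=O)[O-])cc2)CC1` differs by nitro in place of methoxy on an aromatic carbon. No readable step bears on this change, so no direction can be drawn from the series. Compound 4 is estimated at 100000 nM, range 40000 nM to 300000 nM. The expected step of a number no higher from compound 3 to compound 4 (the limit leaves the size open) is therefore none beyond the scatter, with a limit the likely outcome.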

Compound 4, concentration for total growth inhibition: 29300 nM
Beside the measured number, compound 4's estimate is 3.4-fold (0.53 log units) above it, and the stated range ends above it.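

In this assay, within the data shown here, this aromatic position gives the first readable change: nitro in place of methoxy gives an at least 3.4-fold lower number from compound 3 to compound 4 (0.53 log units; beyond the scatter), and nitro in place of hydrogen gives an at least 3.4-fold lower number from compound 2 to compound 4 (0.53 log units; beyond the scatter). Compound 4 alone carries a number, and the step from compound 2 to compound 3 cannot be read: the limit of > 100000 nM in this assay, at which 3 of the 4 values shown sit.

On these data alone, the full size of both new steps stays open, as each starts from a limit. Also open, as far as these compounds go, is whether an amine, a nitrile or a carboxylic acid on the same aromatic carbon would give a number at all.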